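Hydroxyphenyl pyridines: moving the hydroxyl on the ring

The source may report more compounds than this note shows. Statements on the series, on what has been measured and on what is new or still open speak of the compounds shown alone.

Measured so far:
compound 1 `Oc1ccc(-c2cc(-c3ccsc3)nc(-c3cccc(Cl)c3)c2)cc1`, 2670 nM
compound 2 `Oc1cccc(-c2cc(-c3ccccc3)nc(-c3cccc(Cl)c3)c2)c1`, 3120 nM
compound 3 `Oc1cccc(-c2cc(-c3ccncc3)nc(-c3cccc(Cl)c3)c2)c1`, "not determined" (no result reported)

In an ADME assay on HEK293 cells (Homo sapiens) for cytotoxicity, read by CCK-8 assay and cell counting, with a stated time of 2 days (a higher number here means a weaker inhibitor, a lower number a stronger inhibitor), compound 2 gives 3120 nM, the highest of the two numbers; compound 1 sits a little lower at 2670 nM, within the scatter, and compound 3 has no number. Compound 4 `Oc1ccc(-c2cc(-c3ccccc3)nc(-c3cccc(Cl)c3)c2)cc1` differs from compound 2 in one place: 4-hydroxyphenyl in place of 3-hydroxyphenyl on an aromatic carbon. Going by the values given here, no measured pair carries this change, so the expectation rests only on the values of compound 1 and compound 2, which lie close together. Compound 4 is expected to stay near compound 2, with the step of a 1.1-fold lower number from compound 2 to compound 4 (0.05 log units; within the scatter) not beyond the scatter. The estimate for compound 4 in this assay is 2800 nM, between 1400 nM and 5600 nM.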

Compound 4, half-maximal inhibitory concentration: 2820 nM
The estimate for compound 4 lay 1.0-fold (0.00 log units) below the measured number; the measured number falls inside the stated range.
By their numbers in this assay, from the lowest: compounds 1, 4 and 2 (each within the scatter of the next).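

In this assay, the hydroxyl moves on its ring with a 1.1-fold lower number from compound 2 to compound 4 (0.04 log units; within the scatter), so 3-hydroxyphenyl and 4-hydroxyphenyl cannot be told apart at this position opposite the ring nitrogen. Compound 4 also links the earlier pair, since phenyl in place of thiophen-3-yl gives a 1.1-fold higher number from compound 1 to compound 4 (0.02 log units; within the scatter), and neither single change moves the number beyond the scatter. No supporting data bear on why these numbers stay together. Open, on these data alone, is whether an amine or a carboxylic acid in place of the hydroxyl would separate from these values.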